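A Single Aryl Swap in an Antiproliferative Series

This account rests on a few compounds, and the source may have more. Where it says the series, first, only, none or still open, it means among the compounds named here.

In a functional assay on HepG2 cells (Homo sapiens) for antiproliferative activity, read by sulforhodamine B assay, with a stated time of 48 h (a lower number here means a stronger inhibitor, a higher number a weaker inhibitor), compound 1 (`COc1ccc(C=C(C(=O)/C=C/c2cccc(OC)c2OC)C(=O)/C=C/c2cccc(OC)c2OC)cc1OC`) gives 200 nM and compound 2 (`COc1ccc(OC)c(/C=C/C(=O)C(=Cc2cc(OC)c(O)c(OC)c2)C(=O)/C=C/c2cc(OC)ccc2OC)c1`) gives 210 nM, values within the usual scatter of each other. Compound 3 (`COc1ccc(/C=C/C(=O)C(=Cc2ccc(O)c(F)c2)C(=O)/C=C/c2ccc(OC)cc2OC)c(OC)c1`) stands highest of the three at 1760 nM, which makes it the weakest inhibitor among them. Compound 4 (`COc1ccc(/C=C/C(=O)C(=Cc2ccc(OC)c(O)c2)C(=O)/C=C/c2ccc(OC)cc2OC)c(OC)c1`) is still unmeasured and brings 3-hydroxy-4-methoxyphenyl in place of 3-fluoro-4-hydroxyphenyl (3-hydroxy-4-methoxyphenyl in place of 3-fluoro-4-hydroxyphenyl on a double-bonded chain carbon bound to a double-bonded chain carbon). Going by the values given here, no measured pair isolates this change. The entering group carries no fluorine, like its counterparts in compound 1 at 200 nM and compound 2 at 210 nM, so a drop beyond the scatter is expected in this assay. The expected change is a 3.4-fold lower number from compound 3 to compound 4 (0.53 log units; beyond the scatter). For compound 4 the estimated value is 520 nM, with an expected range of 170 nM to 1600 nM.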

Compound 4, half-maximal inhibitory concentration: 390 nM
Beside the measured number, compound 4's estimate is 1.3-fold (0.12 log units) above it; the measured number falls inside the stated range.
By their numbers in this assay, from the lowest: compounds 1, 2 and 4 (each within the scatter of the next); then compound 3.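

Going by these compounds alone, with the rest of the molecule held fixed, 3-hydroxy-4-methoxyphenyl in place of 3-fluoro-4-hydroxyphenyl gives a 4.5-fold lower number from compound 3 to compound 4 (0.65 log units; beyond the scatter) in this assay and is the first single change that can be read. The aryl group on this double-bonded chain carbon can therefore, on its own, move the number beyond the scatter. Nothing available bears on why it does so.

The compounds shown leave open whether losing the fluorine or gaining the methoxy carries the step. A plain 4-hydroxyphenyl or a 3-amino-4-methoxyphenyl group at this place would help separate the two.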